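Piperidin-4-yl Takes the Place of Phenyl on Compound 3

The compounds below may be only part of what the source reports. "The series", "measured", "known", "first", "only" and "open" are said of these compounds alone.

Compound 1, `c1ccc(CN(CCCCN(C[C@H]2Cc3ccccc3CN2)[C@H]2CCCc3cccnc32)Cc2ccccn2)nc1`, gives 664 nM in a functional assay on cells for antagonist activity at C-X-C chemokine receptor type 4 (Homo sapiens), read by fluorescence and calcium flux, with stated times of 25 min and 90 s; a higher number here means a weaker inhibitor, a lower number a stronger inhibitor.
Compound 2, `c1ccc(CN(CCCCN(C[C@H]2Cc3ccccc3CN2)[C@H]2CCCc3cccnc32)Cc2ccccc2)cc1`, reaches only a limit of > 16700 nM in this assay.
Compound 3, `c1ccc(CNCCCCN(C[C@H]2Cc3ccccc3CN2)[C@H]2CCCc3cccnc32)cc1`, gives 20.1 nM in this assay.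

Among the two numbers shown, compound 3 stands lowest; compound 1 sits a step beyond the scatter above it, and compound 2 offers no number but a limit, which is where the limit of > 16700 nM in this assay, at which 1 of the 3 values shown sits, sits. Within the data shown here, the one measured step that involves compound 3 is an at least 830-fold lower number from compound 2 to compound 3 (2.91 log units; beyond the scatter), a very large drop that came from hydrogen in place of benzyl on an amine nitrogen.

Compound 4, `c1ccc2c(c1)CN[C@@H](CN(CCCCNCC1CCNCC1)[C@H]1CCCc3cccnc31)C2`, has not yet been measured. It differs from compound 3 by piperidin-4-yl in place of phenyl on a saturated chain carbon bound to an amine nitrogen. Cut one bond further out, the change reads benzyl to (piperidin-4-yl)methyl.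

Among the measured compounds shown here, no measured step touches this kind of exchange: the step from compound 2 to compound 3 removed a benzyl from the nitrogen entirely, whereas here the benzyl stays in size and only its ring changes. The expectation therefore rests on the sparse evidence alone, and compound 4 is expected to land near compound 3, with a 1.5-fold higher number from compound 3 to compound 4 (0.17 log units; within the scatter) as the estimated step. The estimate for compound 4 in this assay is 30 nM, within a range of 6 nM to 150 nM.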

Compound 4, half-maximal inhibitory concentration: 36.5 nM
Compound 4: middle estimate off by 1.2-fold (0.09 log units), on the low side, and the stated range covers the measured number.
By their numbers in this assay, from the lowest: compounds 3 and 4 (each within the scatter of the next); then compound 1. At a limit, above all of these: compound 2.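

The exchange of phenyl for piperidin-4-yl on a saturated chain carbon bound to an amine nitrogen gives a 1.8-fold higher number from compound 3 to compound 4 (0.26 log units; within the scatter) in this assay, so the two compounds cannot be told apart here. Among these compounds, the only earlier step at this end of the molecule concerned a second benzyl on the amine nitrogen, and it said nothing about the ring of the benzyl that remains; this result shows that an aromatic ring of carbon only can give way at this place to a non-aromatic ring carrying one nitrogen, with a hydrogen-bond donor and acceptor added, and the number stays within the scatter. Nothing measured here accounts for why the number holds through this change.

From the compounds shown here alone, it remains open whether the ring nitrogen of piperidin-4-yl plays any part of its own, a question that a cyclohexyl ring or a pyridin-4-yl ring at this place would address. Also open, going by these compounds, is whether a methyl group on the piperidine nitrogen, or a longer chain between the ring and the amine nitrogen, would keep the number in this range.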